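Working notes: methoxy on the benzyl of compound 3

The source may hold more compounds than are shown below. What is called first, only, known or untested is meant among the compounds shown, and "the series" means these compounds.

Measured so far in a functional assay on MCF7 cells (Homo sapiens) for antiproliferative activity, read by sulforhodamine B assay, with a stated time of 48 h (a lower number here means a stronger inhibitor, a higher number a weaker inhibitor), for this series
- compound 1 `COc1ccc(C[C@@H](O)/C=C/C=C/C(=O)N2CCCCC2)cc1OC` gives 39500 nM
- compound 2 `COc1ccc(C[C@@H](O)/C=C/C=C/C(=O)NCc2ccc(Cl)cc2)cc1OC` gives 18100 nM
- compound 3 `COc1ccc(C[C@@H](O)/C=C/C=C/C(=O)NCc2ccccc2)cc1OC` gives 33600 nM

Compound 3 stands second highest of the three numbers, but within the scatter of both other compounds. Compound 4 `COc1ccc(CNC(=O)/C=C/C=C/[C@H](O)Cc2ccc(OC)c(OC)c2)cc1` is unmeasured and carries methoxy in place of hydrogen on an aromatic carbon, para to a large group (methoxy in place of hydrogen on an aromatic carbon), which takes benzyl to 4-methoxybenzyl.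

The closest evidence is the loss of chloro at this same place, with a 1.9-fold higher number from compound 2 to compound 3 (0.27 log units; within the scatter) as its size. Also relevant is a 2.2-fold lower number from compound 1 to compound 2 (0.34 log units; beyond the scatter) as a modest step, while a 1.2-fold lower number from compound 1 to compound 3 (0.07 log units; within the scatter) shows little from benzylamino alone. For the measured compounds named here, no methoxy compound has been measured, so this rests on very few pairs. No step beyond the scatter is therefore expected in this assay and, if anything, a slightly lower number. The estimate means a 1.2-fold lower number from compound 3 to compound 4 (0.08 log units; within the scatter) as the expected step. For compound 4 the expected value is 28000 nM with an estimated range from 14000 nM to 55000 nM in this assay.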

Compound 4, half-maximal inhibitory concentration: 26600 nM
For compound 4 the middle estimate is 1.1-fold (0.02 log units) above the measured one; the measured number falls inside the stated range.
By their numbers in this assay, from the lowest: compounds 2, 4, 3 and 1 (each within the scatter of the next, the first and the last beyond it).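

In this assay, for the compounds shown here, methoxy is the first group at this place that carries oxygen, and adding its 2 heavy atoms, para to a large group, leaves the number within the scatter: a 1.3-fold lower number from compound 3 to compound 4 (0.10 log units; within the scatter) for the change from hydrogen. The swap from chloro to methoxy at the same place also stays within the scatter, with a 1.5-fold higher number from compound 2 to compound 4 (0.17 log units; within the scatter), so the assay does not separate hydrogen, chloro and methoxy on this benzyl, and this position has so far tolerated all three without a step beyond the scatter. No measurement bearing on the reason for this result is at hand.

Going by these compounds, what an amine or a carboxylic acid would do at this same place remains open. On these data alone, it is also open whether a longer chain, such as butoxy, would produce a step beyond the scatter from compound 3.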